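Amide cap exchange on the shared core: expected cytotoxicity

The source may hold more compounds than are shown below. What is called first, only, known or untested is meant among the compounds shown, and "the series" means these compounds.

Of the compounds shown here, two have numbers so far. Compound 1 `COc1ccccc1C(=O)Nc1ccc2nc(SCC(=O)NCc3ccccc3)sc2c1` in a functional assay on HepG2 cells (Homo sapiens) for cytotoxicity, read by MTT assay, with a stated time of 48 h (a higher number here means a weaker inhibitor, a lower number a stronger inhibitor), gives 8000 nM. Compound 2 `O=C(CSc1nc2ccc(NC(=O)CCl)cc2s1)NCc1ccc(Cl)cc1` in this assay gives 1800 nM, the lowest of the two numbers; its gap to compound 1 lies beyond the scatter. The next member, compound 3 `COc1ccccc1C(=O)Nc1ccc2nc(SCC(=O)NCc3ccc(Cl)cc3)sc2c1`, has not been measured. It differs from compound 2 in one place: 2-methoxyphenyl in place of chloromethyl on a carbonyl carbon, so that a (chloromethyl)carbonyl amino group becomes a (2-methoxyphenyl)carbonyl amino group. Among the compounds with values here, no measured pair isolates this exchange, so no step size is known for it. Because compound 1, which carries the same (2-methoxyphenyl)carbonyl amino group, gives 8000 nM, the number for compound 3 is expected to move up, toward the weaker end, by a step of a 3.3-fold higher number from compound 2 to compound 3 (0.52 log units; beyond the scatter). Compound 3 is accordingly estimated at 6000 nM, with a range from 2000 nM to 20000 nM.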

Compound 3, half-maximal inhibitory concentration: 600 nM
Compound 3: the middle estimate sits 10-fold (1.00 log units) above what was measured; the whole stated range lies above it.
By their numbers in this assay, from the lowest: compound 3; then compound 2; then compound 1.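

On the carbonyl carbon of the amide cap in this assay, 2-methoxyphenyl in place of chloromethyl gives a 3.0-fold lower number from compound 2 to compound 3 (0.48 log units; beyond the scatter), so on this background the chloromethyl group is not required for a low number. The other exchange, chloro in place of hydrogen on an aromatic carbon, gives a 13-fold lower number from compound 1 to compound 3 (1.12 log units; beyond the scatter), a large step that places the aromatic cap at either end of the series depending on that one substituent. No measurement here bears on the reason for either step.

From the compounds shown here alone, the chloro step is read only with the (2-methoxyphenyl)carbonyl amino group, so its size with the (chloromethyl)carbonyl amino group stays open. Also open, going by these compounds, is where a cap ending in an amine or a carboxylic acid, or a longer alkyl chain on the carbonyl carbon, would fall in this assay.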